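Swapping the benzothiazolylamino arm of compound 2 for a triazole

This account rests on a few compounds, and the source may have more. Where it says the series, first, only, none or still open, it means among the compounds named here.

Compound 2 `O=C(NCC1(c2nc(-c3ccccc3)cs2)CCOCC1)c1ccc(Nc2nc3ccccc3s2)cc1` stands lowest of the three compounds measured in a physicochemical assay for solubility, read by chemiluminescence, in phosphate buffer, measured as kinetic solubility, at pH 7.4 (a higher number here means a more soluble compound, a lower number a less soluble compound), where compound 2 gives 4000 nM. Compound 1 `Cn1ccc(Nc2ccc(C(=O)NCC3(c4nc(-c5ccccc5)cs4)CCOCC3)cc2)n1` gives 48000 nM and compound 3 `COc1cccc(-c2csc(C3(CNC(=O)c4ccc(Cn5nc(C)cc5C)cc4)CCOCC3)n2)c1` gives 72000 nM. For the measured compounds named here, the only step between close neighbours, a 12-fold lower number from compound 1 to compound 2 (1.08 log units; beyond the scatter), is large. Compound 4 `O=C(NCC1(c2nc(-c3ccccc3)cs2)CCOCC1)c1ccc(-n2cncn2)cc1` differs from compound 2 by 1H-1,2,4-triazol-1-yl in place of (1,3-benzothiazol-2-yl)amino on an aromatic carbon. The step from compound 1 to compound 2 bears most directly on this change: it altered the same arm of the shared core, and the group now entering is, like that of compound 1, a single small five-membered aromatic ring rather than a two-ring unit. Compound 4 is therefore expected to move upward in this assay by about a 7.5-fold higher number from compound 2 to compound 4 (0.88 log units; beyond the scatter). Compound 4 is estimated at 30000 nM, within a range from 8000 nM to 100000 nM.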

Compound 4, solubility: 191000 nM
Beside the measured number, compound 4's estimate is 6.4-fold (0.80 log units) below it; measured number outside the range, above it.
By their numbers in this assay, from the lowest: compound 2; then compounds 1 and 3 (each within the scatter of the next); then compound 4.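

For the compounds shown here, at this position, on an aromatic carbon para to a large group, this assay spans more than the earlier compounds showed: the triazole gives [ a 48-fold higher number from compound 2 to compound 4 (1.68 log units; beyond the scatter) ]. Single five-membered aromatic rings are also not interchangeable here, as the triazole, attached without an amino link, gives [ a 4.0-fold higher number from compound 1 to compound 4 (0.60 log units; beyond the scatter) ] against the methylpyrazolylamino arm. Nothing shown explains either step. Going by these compounds, it remains open how much depends on the amino link or the ring itself, and how an arm such as a carboxylic acid or a morpholine would compare.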